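A Bromo Group Enters the Fluorophenyl Ring

The source may report more compounds than this note shows. Statements on the series, on what has been measured and on what is new or still open speak of the compounds shown alone.

Three measured compounds share one core and differ only in the aromatic ring attached to the carbon with a double bond to nitrogen. In an assay on tissue (MDA-MB-231 cells) for inhibition of Indoleamine 2,3-dioxygenase 1 (Homo sapiens), read by spectrophotometry, with stated times of 4 h and 5 h (a lower number here means a stronger inhibitor, a higher number a weaker inhibitor), compound 1 `O=[N+]([O-])c1ccc(N/C(=N\O)c2ccccc2F)c2nonc12` gives 131 nM, compound 2 `O=[N+]([O-])c1ccc(N/C(=N\O)c2ccccc2Br)c2nonc12` gives 66 nM, and compound 3 `O=[N+]([O-])c1ccc(N/C(=N\O)c2ccc(F)cc2)c2nonc12` gives 125 nM. Compound 3 holds the second highest of the three numbers, but the differences are small: a 1.0-fold lower number from compound 1 to compound 3 (0.02 log units; within the scatter) and a 1.9-fold higher number from compound 2 to compound 3 (0.28 log units; within the scatter), so no order among the three can be claimed. Compound 4 `O=[N+]([O-])c1ccc(N/C(=N\O)c2ccc(F)c(Br)c2)c2nonc12` has not yet been measured in this assay. It differs from compound 3 by bromo in place of hydrogen on an aromatic carbon. Among the measured compounds shown here, no measured pair shows bromo entering in place of hydrogen, so the evidence is indirect. The closest guide is bromo in place of fluoro on an aromatic carbon, which gave a 2.0-fold lower number from compound 1 to compound 2 (0.30 log units; within the scatter). A small step, if any, is therefore expected: a 1.4-fold lower number from compound 3 to compound 4 (0.14 log units; within the scatter). Compound 4 is estimated at 90 nM, with a range from 40 nM to 220 nM.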

Compound 4, half-maximal inhibitory concentration: 107 nM
Compound 4: the middle estimate sits 1.2-fold (0.08 log units) below what was measured, within the range that was stated.
By their numbers in this assay, from the lowest: compounds 2, 4, 3 and 1 (each within the scatter of the next).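

Among the compounds shown here, compound 4 gives the first direct reading of bromo in place of hydrogen, here on an aromatic carbon ortho to a fluoro group. In this assay this is a 1.2-fold lower number from compound 3 to compound 4 (0.07 log units; within the scatter) and so the added bromo has no readable effect on the number. Likewise, a 1.6-fold higher number from compound 2 to compound 4 (0.21 log units; within the scatter) and a 1.2-fold lower number from compound 1 to compound 4 (0.09 log units; within the scatter) both stay within the scatter, so the 3-bromo-4-fluorophenyl group cannot be told apart here from 2-bromophenyl or 2-fluorophenyl. No measured evidence is available to explain this result.

The compounds shown leave open whether a different group on this same carbon, such as an amine, a methoxy group or a carboxylic acid, would move the number beyond the scatter. They also leave open how bromo on this carbon would read on a phenyl ring without the fluoro group.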